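From prop-1-en-1-yl to allyl on an aromatic carbon

The source may report more compounds than this note shows. Statements on the series, on what has been measured and on what is new or still open speak of the compounds shown alone.

Of the compounds shown here, three have numbers so far in an ADME assay on P3HR-1 cells (Homo sapiens) for cytotoxicity, read by microscopy and trypan blue exclusion, with a stated time of 2 days; on this read-out higher numbers stand for lower toxicity in this test and lower numbers for higher toxicity in this test. Compound 1 (`COc1cc([C@@H](O)[C@@H](C)Oc2ccc([C@@H]3O[C@H](c4ccc(O)c(OC)c4)[C@H](C)[C@H]3C)cc2OC)ccc1O`) gives 23200 nM, and compound 3 (`COc1cc([C@H]2O[C@@H](c3cc(OC)c(OC)c(OC)c3)[C@H](C)[C@@H]2C)cc(O)c1OC`) gives 32000 nM. Compound 2 (`C/C=C/c1cc(OC)c(O[C@H](C)[C@H](OC(C)=O)c2cc(OC)c(OC)c(OC)c2)c(OC)c1`) stands highest of the three at 76800 nM, beyond the scatter of both others.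

Compound 4 (`C=CCc1cc(OC)c(O[C@H](C)[C@H](OC(C)=O)c2cc(OC)c(OC)c(OC)c2)c(OC)c1`) has not yet been measured in this assay. It carries allyl in place of prop-1-en-1-yl on an aromatic carbon, meta to two methoxy groups and para to a large group: allyl in place of prop-1-en-1-yl on an aromatic carbon. The two compounds have the same atoms, joined differently.

Going by the values given here, no two measured compounds differ in one place only, so the data show no step for this change. The expectation therefore starts from compound 2 at 76800 nM, and no shift beyond the scatter is foreseen. The expected step is small and downward, a 1.1-fold lower number from compound 2 to compound 4 (0.04 log units; within the scatter). Compound 4 is estimated at 70000 nM, with an expected range of 35000 nM to 140000 nM.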

Compound 4, half-maximal cytotoxic concentration: 85000 nM
The estimate for compound 4 lay 1.2-fold (0.08 log units) below the measured number; low and high end bracket the measured number.
By their numbers in this assay, from the lowest: compounds 1 and 3 (each within the scatter of the next); then compounds 2 and 4 (each within the scatter of the next).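

Going by these compounds alone, this is the first step that touches one place only, and in this assay allyl in place of prop-1-en-1-yl on an aromatic carbon gives a 1.1-fold higher number from compound 2 to compound 4 (0.04 log units; within the scatter) and leaves the two compounds indistinguishable on this read-out. At this position, meta to two methoxy groups and para to a large group, the two chains, each with one double bond outside aromatic rings, are therefore interchangeable in this test, as far as this single pair shows. Nothing at hand offers a reason for this result.

On these data alone, whether the same carbon would accept a saturated propyl chain, a longer chain, an amine or a carboxylic acid remains open. Also open, as far as these compounds go, is whether this exchange would read the same way with the shared core altered elsewhere.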